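This account rests on a few compounds, and the source may have more. Where it says the series, first, only, none or still open, it means among the compounds named here.

Measured so far in an ADME assay on microsomes from liver (Homo sapiens) for metabolic stability, read by LC-MS, with a stated time of 30 min, tested at 0.1 uM; on this read-out lower numbers stand for a less stable compound and higher numbers for a more stable compound: compound 1 `FC(F)(F)c1cccc(-c2nc3cnc(Nc4ccccn4)cc3[nH]2)c1` gives 69%; compound 2 `FC(F)(F)Oc1ccc(-c2nc3cnc(Nc4ccccn4)cc3[nH]2)cc1` gives 60%.

Of the two numbers compound 1 gives the larger, but its gap to compound 2 lies within the scatter, so the pair reads as alike. Compound 3 `COc1cccc(Nc2cc3[nH]c(-c4cccc(C(F)(F)F)c4)nc3cn2)n1` carries methoxy in place of hydrogen on an aromatic carbon. Among the compounds with values here, no step between measured compounds covers this change, so the expectation rests on compound 1 alone. For compound 3 a step of a number 11 percentage points lower from compound 1 to compound 3 (beyond the scatter) is expected, at most slight and downward, not clearly beyond the scatter. Compound 3 is thus estimated at 58%, between 35% and 80%.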

Compound 3, percent of the compound remaining: 45%
Compound 3: middle estimate off by 13 percentage points, on the high side; the range from low to high includes it.
By their numbers in this assay, from the lowest: compound 3; then compounds 2 and 1 (each within the scatter of the next).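

In this assay, going from pyridin-2-yl to 6-methoxypyridin-2-yl gives a number 24 percentage points lower from compound 1 to compound 3 (beyond the scatter), the first step read at this position. This position is therefore not indifferent to substitution: methoxy on the aromatic carbon next to the ring nitrogen shifts the read-out towards a less stable compound. Nothing available accounts for this shift.

From the compounds shown here alone, whether an amine, a fluorine atom or a longer ether chain at the same place gives a similar step remains open. So does whether methoxy at this place has the same effect with the side group of compound 2.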